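The compounds below may be only part of what the source reports. "The series", "measured", "known", "first", "only" and "open" are said of these compounds alone.

For the measured compounds named here, in a functional assay on HCT-116 cells (Homo sapiens) for inhibition, read by CCK-8 assay, with a stated time of 48 h (a lower number here means a stronger inhibitor, a higher number a weaker inhibitor), compound 1 `COc1cc(-c2ccnc3cc(-c4ccc(C)c(C)c4)nn23)cc(OC)c1OC` gives 261 nM while compound 2 `COc1cc(-c2ccnc3cc(-c4ccc5ccn(C)c5c4)nn23)cc(OC)c1OC` gives 1040 nM as the higher of the only two numbers so far, which makes it the weaker inhibitor of the pair. Compound 3 `COc1ccc(-c2cc3nccc(-c4cc(OC)c(OC)c(OC)c4)n3n2)cc1F` keeps the shared core and differs from compound 2 in a single group, with 3-fluoro-4-methoxyphenyl in place of 1-methyl-1H-indol-6-yl on an aromatic carbon. Going by the values given here, the one measured step that bears on this is a 4.0-fold higher number from compound 1 to compound 2 (0.60 log units; beyond the scatter) (modest, but beyond the scatter), where 1-methyl-1H-indol-6-yl stands in place of 3,4-dimethylphenyl. Compound 3 gives up that same group and, like compound 1, carries one six-membered aromatic ring of carbon only at this place. A move toward a lower number is therefore expected in this assay of similar or somewhat smaller size. Among the compounds with values here, no measured compound carries 3-fluoro-4-methoxyphenyl, and only one step supports the expectation, so the size remains uncertain. The expected change is a 3.3-fold lower number from compound 2 to compound 3 (0.51 log units; beyond the scatter) as an estimate. Compound 3 is thus estimated at 320 nM (expected range 100 nM to 1000 nM).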

Compound 3, half-maximal inhibitory concentration: 2840 nM
For compound 3 the middle estimate is 8.9-fold (0.95 log units) below the measured one; measured number outside the range, above it.
By their numbers in this assay, from the lowest: compound 1; then compound 2; then compound 3.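

The new result shows that having one six-membered aromatic ring of carbon only at this place does not by itself give a lower number. In this assay, the change to 3-fluoro-4-methoxyphenyl gives a 2.7-fold higher number from compound 2 to compound 3 (0.44 log units; beyond the scatter), and the comparison with the 3,4-dimethylphenyl group gives an 11-fold higher number from compound 1 to compound 3 (1.04 log units; beyond the scatter). The two groups with a single ring therefore sit at opposite ends of the three numbers, with the two-ring 1-methyl-1H-indol-6-yl group between them, so at this place the groups carried on the ring separate the compounds more widely than the number of rings does. Nothing shown here gives a measured reason for this change. Going by these compounds, compound 3 differs from compound 1 in both ring substituents at once, so the fluorine and the methoxy group cannot be judged separately, and it remains open how the number would change with only one of them, or with an amine or a carboxylic acid on the same ring.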